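Piperazine substituent swap on a benzamide dithiocarbamate series

The source may report more compounds than this note shows. Statements on the series, on what has been measured and on what is new or still open speak of the compounds shown alone.

Compound 1: `CC1CCCCN1C(=S)SCc1ccc(C(=O)Nc2ccccc2N)cc1` with 86.9%
Compound 2: `N#Cc1ccc(N2CCN(C(=S)SCc3ccc(C(=O)Nc4ccccc4N)cc3)CC2)cc1` with 37.6%
Compound 3: `CCN(Cc1ccncc1)C(=S)SCc1ccc(C(=O)Nc2ccccc2N)cc1` with 85.2%

In a functional assay on MGC-803 cells (Homo sapiens) for antiproliferative activity, read by CCK-8 assay, with a stated time of 72 h, tested at 8 uM (on this read-out higher numbers stand for a stronger effect at the one concentration tested and lower numbers for a weaker effect), compound 2 gives 37.6%, the lowest of the three numbers. Compound 3 stands nearest to it, a number beyond the scatter higher, and compound 1 stands furthest. Compound 1 and compound 3 differ only at the thiocarbonyl carbon, and that step, a number 1.7 percentage points lower from compound 1 to compound 3 (within the scatter), lies within the scatter, so the shared core tolerates very different amines on that position.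

Compound 4, `Nc1ccccc1NC(=O)c1ccc(CSC(=S)N2CCN(Cc3cccnc3)CC2)cc1`, is reached from compound 2 by one change: (pyridin-3-yl)methyl in place of 4-cyanophenyl on an amine nitrogen in a ring. Within the data shown here, no measured step covers this exact change. The step from compound 1 to compound 3 touched a different part of the molecule and was flat, so it gives no guidance on direction. Among the measured compounds shown here, what the numbers do show is that compound 2 is the only compound carrying a 4-cyanophenyl and the only one far below the others.

Compound 4 is therefore expected to move upward, with a step of a number 32.4 percentage points higher from compound 2 to compound 4 (beyond the scatter) in this assay, because compound 3 gives 85.2% with a pyridinylmethyl group on its amine nitrogen. The estimate for compound 4 is 70%, within a range from 45% to 90%.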

Compound 4, a percentage reported as inhibition, at one concentration (the size of the read-out at that concentration, not a potency): 64.6%
The estimate for compound 4 lay 5.4 percentage points above the measured number; low and high end bracket the measured number.
By their numbers in this assay, from the lowest: compound 2; then compound 4; then compounds 3 and 1 (each within the scatter of the next).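

Among these compounds, on an amine nitrogen in a ring, (pyridin-3-yl)methyl in place of 4-cyanophenyl gives, in this assay, a number 27 percentage points higher from compound 2 to compound 4 (beyond the scatter), which shows that the read-out responds to the group at this position, unlike the flat step on the thiocarbonyl carbon among the earlier compounds. The two groups carry the same counts of hydrogen-bond donors and acceptors and no net charge, so these counts do not separate them, while the triple bond leaves and a ring with 1 hetero atom enters within the same single change. Nothing in the data given accounts for this step.

The compounds shown leave open which part of the change goes with the higher number, since a plain phenyl group on the same nitrogen would separate the loss of the nitrile from the change of ring, and a benzyl group would test the ring nitrogen of the entering group. Also open, going by these compounds, is how the number would respond to a small alkyl group such as methyl at this position, where no aromatic ring is present at all.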